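From a Tert-Butyl Ester to a Phenyl Ester

A few compounds are considered here, and "the series" means these few. Any claim that something is new, unique, unknown or untested is made for them only; others in the source may bear on it.

Of the compounds shown here, three have been tested in a functional assay on the whole organism (strain Sprague-Dawley CD) for inhibition, with Rattus norvegicus as the target, read by paw edema, at a dose of 100 mg/kg by the oral route; on this read-out lower numbers stand for a weaker effect and higher numbers for a stronger effect at the one dose given. Compound 1, `CCOC(=O)C(=O)Nc1cccccc1=O`, gives 91%. Within the data shown here, compound 3, `CC(C)(C)OC(=O)C(=O)Nc1cccccc1=O`, gives 82%; the single change between them, tert-butyl in place of ethyl on an oxygen next to a carbonyl group, gave a number 9 percentage points lower from compound 1 to compound 3 (within the scatter). Compound 2, `CCOC(=O)C(=O)Nc1c(Oc2ccccc2)ccccc1=O`, gives 20%; its change, phenoxy in place of hydrogen on an aromatic carbon, gave a number 71 percentage points lower from compound 1 to compound 2 (beyond the scatter). Compound 3 therefore sits alongside compound 1 on this read-out and far from compound 2.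

Compound 4, `O=C(Nc1cccccc1=O)C(=O)Oc1ccccc1`, differs from compound 3 in one place: phenyl in place of tert-butyl on an oxygen next to a carbonyl group. Among the measured compounds shown here, the only earlier step at this same place, on an oxygen next to a carbonyl group, is the exchange of ethyl for tert-butyl, which stayed within the scatter. The large fall seen with compound 2 concerns an aromatic carbon, a different place, so it does not speak directly to this change. On this basis a step no larger than the scatter is expected, leaning slightly downward since a larger group enters. The expected step is a number 10 percentage points lower from compound 3 to compound 4 (within the scatter). Compound 4 is expected to give 72%, within a range from 45% to 92%.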

Compound 4, a percentage reported as inhibition, in the whole organism at one dose (the size of the read-out at that dose, not a potency): 71%
The estimate for compound 4 lay 1 percentage points above the measured number; the range from low to high includes it.
By their numbers in this assay, from the lowest: compound 2; then compound 4; then compounds 3 and 1 (each within the scatter of the next).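

In this assay, among these compounds, phenyl in place of tert-butyl on an oxygen next to a carbonyl group gave a number 11 percentage points lower from compound 3 to compound 4 (beyond the scatter), the first step at this place to pass beyond the scatter. Measured against the ethyl group of the first compound, phenyl gave a number 20 percentage points lower from compound 1 to compound 4 (beyond the scatter), so this place is not indifferent to what it carries, even though both steps are modest in size. No measurement here explains why the number falls with phenyl.

The compounds shown leave open whether the aromatic ring itself or simply the larger group goes with the lower number, a question that cyclohexyl on the same oxygen could help to settle. Benzyl, which holds a carbon chain link between that oxygen and the phenyl ring, would show whether the ring's distance from the oxygen matters.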